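The source may report more compounds than this note shows. Statements on the series, on what has been measured and on what is new or still open speak of the compounds shown alone.

Measured in a functional assay on A549 cells (Homo sapiens) for cytotoxicity, read by MTT assay, with a stated time of 72 h; on this read-out higher numbers stand for weaker inhibition and lower numbers for stronger inhibition:
- compound 1 `O=C(N/N=C/c1ccc([N+](=O)[O-])cc1)Nc1cc2c(Nc3ccc(F)c(Cl)c3)ncnc2cc1O[C@H]1CCOC1`: 31200 nM
- compound 2 `COc1cc2ncnc(Nc3ccc(F)c(Cl)c3)c2cc1NC(=O)N/N=C/c1ccc([N+](=O)[O-])cc1`: 35100 nM

In this assay, for the measured compounds named here, compound 2 at 35100 nM sits level with compound 1 at 31200 nM, and these are the only two numbers available. Nothing yet shows how far this series can move in either direction.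

The next compound is compound 3 `COc1cc2ncnc(Nc3ccc(F)c(Cl)c3)c2cc1NC(=O)N/N=C/c1ccc(O)c(Br)c1`, and the change from compound 2 is 3-bromo-4-hydroxyphenyl in place of 4-nitrophenyl on a carbon with a double bond to nitrogen. Going by the values given here, only one measured step exists, a 1.1-fold higher number from compound 1 to compound 2 (0.05 log units; within the scatter), and it stays within the scatter. That step exchanges oxolan-3-yl for methyl on an oxygen on an aromatic ring, so it says nothing directly about a new group on a carbon with a double bond to nitrogen. Among the compounds with values here, no measured compound varies that group, which leaves the direction of any shift in this assay unknown. The expectation is therefore no step beyond the scatter, held with wide uncertainty. The expected step is a 1.3-fold lower number from compound 2 to compound 3 (0.10 log units; within the scatter). For compound 3 the estimated value is 28000 nM, with an expected range from 9000 nM to 70000 nM.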

Compound 3, half-maximal inhibitory concentration: 28600 nM
Compound 3: middle estimate off by 1.0-fold (0.01 log units), on the low side; the range from low to high includes it.
By their numbers in this assay, from the lowest: compounds 3, 1 and 2 (each within the scatter of the next).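

In this assay, the only measured variation at the carbon with a double bond to nitrogen, 3-bromo-4-hydroxyphenyl in place of 4-nitrophenyl, gives a 1.2-fold lower number from compound 2 to compound 3 (0.09 log units; within the scatter), which lies within the scatter. The two groups are not close relatives by what is counted: the entering group carries a bromine and 1 hydrogen-bond donor, while the leaving group has a nitrogen, 2 oxygens and 0 hydrogen-bond donors, and still compound 2 and compound 3 cannot be told apart in this assay's numbers. No measurement is at hand that bears on why the two compounds sit level.

Whether an amine, a carboxylic acid or a longer chain on this carbon would give a step beyond the scatter stays open, since the compounds shown carry only these two phenyl groups there. Also open, as far as these compounds go, is whether 3-bromo-4-hydroxyphenyl would stay level with compound 1 on the oxolan-3-yl side of the series, and whether a plain phenyl or a 4-hydroxyphenyl alone would behave as compound 3 does.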